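The source may report more compounds than this note shows. Statements on the series, on what has been measured and on what is new or still open speak of the compounds shown alone.

In an ADME assay on microsomes from liver (Homo sapiens) for pharmacokinetics (on this read-out lower numbers stand for slow clearance and higher numbers for fast clearance), compound 3 `Cc1ccc(S(=O)(=O)N[C@@H](CC(=O)NC(C)(C)C)C(=O)NCCNC(=O)c2ccc(F)cc2)cc1` gives 149 mL.min-1.g-1 and sits within the scatter of both other measured compounds. Compound 1 `Cc1ccc(S(=O)(=O)N[C@@H](CC(=O)NC(C)(C)C)C(=O)NCCNC(=O)c2ccccc2)cc1` gives 122 mL.min-1.g-1 in this assay and compound 2 `COc1cccc(C(=O)NCCNC(=O)[C@H](CC(=O)NC(C)(C)C)NS(=O)(=O)c2ccc(C)cc2)c1` gives 202 mL.min-1.g-1 in the same read-out. Compound 4 `C#Cc1cccc(C(=O)NCCNC(=O)[C@H](CC(=O)NC(C)(C)C)NS(=O)(=O)c2ccc(C)cc2)c1` differs from compound 3 as follows: 3-ethynylphenyl in place of 4-fluorophenyl on a carbonyl carbon with 3-ethynylphenyl in place of 4-fluorophenyl on a carbonyl carbon. Within the data shown here, three measured steps concern the group on that carbonyl carbon: a 1.2-fold higher number from compound 1 to compound 3 (0.09 log units; within the scatter) with fluoro in place of hydrogen, a 1.7-fold higher number from compound 1 to compound 2 (0.22 log units; within the scatter) with methoxy in place of hydrogen, and a 1.4-fold lower number from compound 2 to compound 3 (0.13 log units; within the scatter) with 4-fluorophenyl in place of 3-methoxyphenyl. All three lie within the scatter. Among the measured compounds shown here, no compound carrying an ethynyl group has been measured, so the expectation rests on these three steps alone. No step beyond the scatter is expected in this assay and no firm direction can be given. The estimated step is a 1.1-fold higher number from compound 3 to compound 4 (0.04 log units; within the scatter) in this read-out. Compound 4 is expected at 165 mL.min-1.g-1 with an estimated range from 90 mL.min-1.g-1 to 300 mL.min-1.g-1 in this assay once measured.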

Compound 4, intrinsic clearance in microsomes: 61 mL.min-1.g-1
Compound 4: middle estimate off by 2.7-fold (0.43 log units), on the high side; the whole stated range lies above it.
By their numbers in this assay, from the lowest: compounds 4, 1, 3 and 2 (each within the scatter of the next, the first and the last beyond it).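

In this assay the group on the carbonyl carbon now produces steps beyond the scatter, which no earlier change there did: 3-ethynylphenyl in place of 4-fluorophenyl gives a 2.4-fold lower number from compound 3 to compound 4 (0.39 log units; beyond the scatter) and ethynyl in place of methoxy gives a 3.3-fold lower number from compound 2 to compound 4 (0.52 log units; beyond the scatter) in this series. Ethynyl in place of hydrogen, by contrast, gives a 2.0-fold lower number from compound 1 to compound 4 (0.30 log units; within the scatter), so the separation holds only against the methoxy and fluoro compounds and not against the compound without a substituent. Nothing measured here bears on the reason for these steps.

Open, on these data alone, is whether a nitrile or a longer alkyne chain in place of the ethynyl group would give a similar number. Also open, as far as these compounds go, is whether 4-ethynylphenyl on the carbonyl carbon would match 3-ethynylphenyl.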